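Swapping one five-membered ring for another in a cell assay

The compounds below may be only part of what the source reports. "The series", "measured", "known", "first", "only" and "open" are said of these compounds alone.

Compound 1 `Cc1nnc(SCc2cc(=O)c3cc(Cl)ccc3o2)o1`: > 25000 nM
Compound 2 `Nc1nnc(SCc2cc(=O)c3cc(Cl)ccc3o2)s1`: > 25000 nM
Compound 3 `Cc1nnc(SCc2coc3ccccc3c2=O)o1`: 3500 nM

In a functional assay on LM7 cells (Homo sapiens) for cytotoxicity, read by MTT assay, with a stated time of 72 h (a higher number here means a weaker inhibitor, a lower number a stronger inhibitor), compound 1 gives > 25000 nM, which is a limit of the assay and not a number. Compound 2 likewise gives only a limit, > 25000 nM. Compound 3 gives 3500 nM. The change from compound 1 to compound 2 is 5-amino-1,3,4-thiadiazol-2-yl in place of 5-methyl-1,3,4-oxadiazol-2-yl on a sulfur, and its step that the two limits leave unreadable from compound 1 to compound 2 cannot be read because both values sit at the limit of > 25000 nM in this assay, at which 2 of the 3 values shown sit. Compound 4 `Nc1nnc(SCc2coc3ccccc3c2=O)s1` has not been measured; it differs from compound 3 by 5-amino-1,3,4-thiadiazol-2-yl in place of 5-methyl-1,3,4-oxadiazol-2-yl on a sulfur, the same change at the same place. How the core of compound 3 differs from the core of compound 1 is not broken down here. With the earlier step unreadable, the expectation rests on compound 3 alone, whose value is 3500 nM. The step of a 1.4-fold higher number from compound 3 to compound 4 (0.15 log units; within the scatter) is expected to be small. Compound 4 is estimated at 5000 nM, between 1500 nM and 25000 nM.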

Compound 4, half-maximal inhibitory concentration: 730 nM
Estimate against measurement, compound 4: 6.8-fold (0.84 log units) above, and the stated range ends above it.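

In this assay, putting 5-amino-1,3,4-thiadiazol-2-yl in place of 5-methyl-1,3,4-oxadiazol-2-yl on the sulfur gives a 4.8-fold lower number from compound 3 to compound 4 (0.68 log units; beyond the scatter), a modest but real gain on the core of compound 3. On the core of compound 1 the same change cannot be read, since compound 1 and compound 2 each give only a limit of the assay and not a number: the limit of > 25000 nM in this assay, at which 2 of the 4 values shown sit. The change is therefore seen to work on one core only, and whether it carries over from one core to the other remains unshown.

On these data alone, it also stays open whether the gain belongs to the amino group or to the ring that bears it. A 5-methyl-1,3,4-thiadiazol-2-yl or a 5-amino-1,3,4-oxadiazol-2-yl on the same sulfur would separate the two.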